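A Second Fluoro on Compound 2

The source may hold more compounds than are shown below. What is called first, only, known or untested is meant among the compounds shown, and "the series" means these compounds.

In a functional assay (aorta) for inhibition, with Rattus norvegicus as the target (a higher number here means that more compound is needed for the effect, a lower number that less compound is needed), compound 1 `O=C1C(Nc2ccc(I)cc2)=CC(=O)c2ncccc21` gives 214 nM, while compound 2 `O=C1C=C(Nc2ccc(F)cc2)C(=O)c2cnccc21` gives 1230 nM, the higher of the two numbers and beyond the usual scatter. Compound 3 `O=C1C=C(Nc2ccc(F)c(F)c2)C(=O)c2cnccc21` differs from compound 2 by fluoro in place of hydrogen on an aromatic carbon, ortho to a fluoro group and meta to a large group (fluoro in place of hydrogen on an aromatic carbon). Among the measured compounds shown here, no pair of measured compounds shows this change alone, so the expectation is loose. In this assay the expected step is a 1.2-fold lower number from compound 2 to compound 3 (0.09 log units; within the scatter), none beyond the scatter. Compound 3 is estimated at 1000 nM, with an expected range from 400 nM to 2500 nM.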

Compound 3, half-maximal effective concentration: 640 nM
The estimate for compound 3 lay 1.6-fold (0.19 log units) above the measured number; the range from low to high includes it.
By their numbers in this assay, from the lowest: compound 1; then compounds 3 and 2 (each within the scatter of the next).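

In this assay, fluoro in place of hydrogen on an aromatic carbon, ortho to a fluoro group and meta to a large group, gives a 1.9-fold lower number from compound 2 to compound 3 (0.28 log units; within the scatter) and so stays within the scatter. On this evidence, the position takes a second fluoro with no shift that can be told from repeat measurements. Nothing at hand bears on why the numbers fall as they do. As far as these compounds go, whether chloro, methoxy or an amine at this position would behave the same remains open, as does whether this change would read alike on the core of compound 1.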